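Swapping Methyl for Chloro on the Fused Ring

A few compounds are considered here, and "the series" means these few. Any claim that something is new, unique, unknown or untested is made for them only; others in the source may bear on it.

Compound 3 `Cc1ccc2c(c1)C[C@@H](O)C[C@@H](c1ccccc1Cl)N2` has the lowest number of the two plain numbers measured here. In an ADME assay on THP-1 cells (Homo sapiens) for cytotoxicity, read by MTT assay, with a stated time of 72 h (on this read-out lower numbers stand for higher toxicity in this test and higher numbers for lower toxicity in this test), compound 3 gives 85200 nM. Compound 1 `O[C@@H]1Cc2cc(Cl)ccc2N[C@H](c2ccccc2)C1` gives 188000 nM in this assay, a step of an at least 3.5-fold lower number from compound 2 to compound 3 (0.54 log units; beyond the scatter) away in the other direction is not available for it, but its number sits higher than that of compound 3. Compound 2 `O[C@@H]1Cc2ccccc2N[C@H](c2ccccc2Cl)C1` gives > 300000 nM in this assay, which is a limit of the measurement and not a number. One value therefore sits at the limit of > 300000 nM in this assay, at which 1 of the 3 values shown sits.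

Among the measured compounds shown here, the only measured step at the same place is an at least 3.5-fold lower number from compound 2 to compound 3 (0.54 log units; beyond the scatter). Compound 4 `O[C@@H]1Cc2cc(Cl)ccc2N[C@H](c2ccccc2Cl)C1` differs from compound 3 by chloro in place of methyl on an aromatic carbon. For the measured compounds named here, no measured step swaps one of these two small groups for the other on this ring, so the expectation rests on the modest size of the hydrogen-to-methyl step alone. Compound 4 is therefore expected to give about 75000 nM in this assay, most likely between 30000 nM and 200000 nM. That estimate means a step of a 1.1-fold lower number from compound 3 to compound 4 (0.06 log units; within the scatter), which is expected to stay within the scatter.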

Compound 4, half-maximal cytotoxic concentration: 75500 nM
Beside the measured number, compound 4's estimate is 1.0-fold (0.00 log units) below it; low and high end bracket the measured number.
By their numbers in this assay, from the lowest: compounds 4 and 3 (each within the scatter of the next); then compound 1. At a limit, above all of these: compound 2.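

Chloro and methyl on this aromatic carbon of the fused ring cannot be told apart in this assay, as a 1.1-fold lower number from compound 3 to compound 4 (0.05 log units; within the scatter) stays within the scatter. Chloro in place of hydrogen at this place gives an at least 3.9-fold lower number from compound 2 to compound 4 (0.59 log units; beyond the scatter), so both small groups go with a lower number than hydrogen, though this step starts from a limit and not from a plain number: the limit of > 300000 nM in this assay, at which 1 of the 4 values shown sits.

Chloro on the other aromatic ring also counts, since adding it to a compound that already has chloro on the fused ring gives a 2.5-fold lower number from compound 1 to compound 4 (0.40 log units; beyond the scatter).

Going by these compounds, whether other groups on this carbon, such as an amine, a carboxylic acid or a longer chain, would fit the same picture stays open. So does whether methyl and chloro would also match on the other aromatic ring.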